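Series notes: 4-fluorobenzyl to 4-nitrobenzyl

The source may report more compounds than this note shows. Statements on the series, on what has been measured and on what is new or still open speak of the compounds shown alone.

Of the compounds shown here, three have been read so far in a functional assay on Bel7402/5-FU cells (Homo sapiens) for antiproliferative activity, read by MTT assay, with a stated time of 72 h; on this read-out higher numbers stand for weaker inhibition and lower numbers for stronger inhibition. Compound 1 `C=C1C(=O)O[C@H]2[C@H]1CC/C(Cn1cc(Cn3cc(F)c(=O)[nH]c3=O)nn1)=C\CC[C@@]1(C)O[C@@H]21` gives > 20000 nM, which is a limit of the assay and not a number. Compound 2 `C=C1C(=O)O[C@H]2[C@H]1CC/C(COC(=O)CCC(=O)NCCCCCCNC(=O)Cn1cc(F)c(=O)n(Cc3ccccc3)c1=O)=C\CC[C@@]1(C)O[C@@H]21` gives 16200 nM. Compound 3 `C=C1C(=O)O[C@H]2[C@H]1CC/C(COC(=O)Cn1cc(F)c(=O)n(Cc3ccc(F)cc3)c1=O)=C\CC[C@@]1(C)O[C@@H]21` gives 1140 nM. This is the lower of the two actual numbers, and its gap to the value of compound 2 lies beyond the usual scatter. These three compounds differ in more than one place, so no gap among them isolates a single change.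

The next compound to be read is compound 4 `C=C1C(=O)O[C@H]2[C@H]1CC/C(COC(=O)Cn1cc(F)c(=O)n(Cc3ccc([N+](=O)[O-])cc3)c1=O)=C\CC[C@@]1(C)O[C@@H]21`. It keeps all of compound 3 except one group, with nitro in place of fluoro on an aromatic carbon, para to a large group (nitro in place of fluoro on an aromatic carbon). Going by the values given here, no measured pair tests a substituent at this place, so the expectation starts from compound 3 at 1140 nM. No step beyond the scatter is expected in this assay, with only a slight lean towards a higher number. The expected step runs a 1.3-fold higher number from compound 3 to compound 4 (0.12 log units; within the scatter). For compound 4 the estimated value is 1500 nM, within an expected range of 450 nM to 5000 nM.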

Compound 4, half-maximal inhibitory concentration: 4340 nM
Estimate against measurement, compound 4: 2.9-fold (0.46 log units) below, and the stated range covers the measured number.
By their numbers in this assay, from the lowest: compound 3; then compound 4; then compound 2. At a limit, above all of these: compound 1.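

In this assay, the change from 4-fluorobenzyl to 4-nitrobenzyl gives a 3.8-fold higher number from compound 3 to compound 4 (0.58 log units; beyond the scatter), so the substituent at this place on the aromatic ring does affect the read-out, though the step is modest. Going by these compounds alone, this is the first comparison that isolates a single change, as the earlier compounds differ in more than one place and could not assign any gap to this ring. Compound 1 alone sits at a limit, so this step is read between two actual numbers and not against that limit: the limit of > 20000 nM in this assay, at which 1 of the 4 values shown sits.

Within the data shown here, two substituents give only one step, which sets fluoro and nitro apart in this assay but supports no trend across substituents and assigns no cause to the change. Going by these compounds, how an amine, a methoxy group or a carboxylic acid would read at this place remains open, as does an unsubstituted benzyl on the short ester link of compound 3, since compound 2 carries that benzyl only on a longer chain.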